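The source may hold more compounds than are shown below. What is called first, only, known or untested is meant among the compounds shown, and "the series" means these compounds.

- Compound 1 `CC1=C(/C=C/C(=O)/C=C/c2ccccc2F)C(C)(C)CCC1` gives 22100 nM
- Compound 2 `CC1=C(/C=C/C(=O)/C=C/c2cccc([N+](=O)[O-])c2)C(C)(C)CCC1` gives 10000 nM
- Compound 3 `CC1=C(/C=C/C(=O)/C=C/c2cccc(C)c2)C(C)(C)CCC1` gives 35000 nM

All three values come from a functional assay on PC-3 cells (Homo sapiens) for cytotoxicity, read by MTT assay, with a stated time of 72 h; a lower number here means a stronger inhibitor, a higher number a weaker inhibitor. Two measured steps show where compound 3 stands. The first is a 1.6-fold higher number from compound 1 to compound 3 (0.20 log units; within the scatter), so that pair cannot be told apart. The second is a 3.5-fold higher number from compound 2 to compound 3 (0.54 log units; beyond the scatter), a modest but real gap.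

Compound 4 `CC1=C(/C=C/C(=O)/C=C/c2cccc(C)c2)C(C)(C)CCC1O` is compound 3 with hydroxy in place of hydrogen on a saturated ring carbon. Neither measured step touches that ring carbon. Within the data shown here, both change the aromatic part of the molecule, and no measured compound carries a hydroxy, so the data offer no direct guide to this change. They show only the size of move seen so far in this small set, at most the modest 3.5-fold higher number from compound 2 to compound 3 (0.54 log units; beyond the scatter).

In this assay, no step beyond the scatter is therefore expected, and neither direction is clearly favoured. The expected change is a 1.2-fold lower number from compound 3 to compound 4 (0.07 log units; within the scatter). The estimate for compound 4 is 30000 nM, with an expected range from 12000 nM to 70000 nM.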

Compound 4, half-maximal inhibitory concentration: 6200 nM
Compound 4: middle estimate off by 4.8-fold (0.68 log units), on the high side, outside the stated range (below it).
By their numbers in this assay, from the lowest: compounds 4 and 2 (each within the scatter of the next); then compounds 1 and 3 (each within the scatter of the next).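

In this assay, hydroxy in place of hydrogen on a saturated ring carbon, on the ring carbon next to the ring atom that bears a methyl group, gives a 5.6-fold lower number from compound 3 to compound 4 (0.75 log units; beyond the scatter). Among these compounds, the earlier steps changed only the aromatic part, so this is the first sign that the saturated ring also affects the number: a single added heavy atom there moves it about as far as the aromatic change in a 3.5-fold higher number from compound 2 to compound 3 (0.54 log units; beyond the scatter). Nothing available explains why this one hydroxy makes compound 4 the stronger inhibitor of the pair, and no separate measurement bears on the cause.

On these data alone, it remains open whether the effect belongs to hydroxy itself or would also appear with a methoxy group, an amine or a ketone carbonyl on the same ring carbon, and whether this ring carbon is special compared with the other saturated ring carbons. As far as these compounds go, it is also open whether the same hydroxy would lower the number when the aromatic ring carries fluoro or nitro, as in compound 1 and compound 2, rather than methyl.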